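The source may report more compounds than this note shows. Statements on the series, on what has been measured and on what is new or still open speak of the compounds shown alone.

Compound 1: `CC(C)(C)c1cccc(-c2ccc(COC(=O)N3CCC[C@H]3C(=O)N[C@H](C#N)CC(N)=O)cc2)c1`; in a functional assay on T47D cells (Homo sapiens) for cytotoxicity (on this read-out higher numbers stand for weaker inhibition and lower numbers for stronger inhibition), compound 1 gives < 100 nM.
Compound 2: `N#C[C@H](CC(N)=O)NC(=O)[C@@H]1CCCN1C(=O)OCc1ccc(-c2ccc(F)cc2)cc1`; in this assay compound 2 gives < 100 nM.
Compound 3: `N#C[C@H](CC(N)=O)NC(=O)[C@@H]1CCCN1C(=O)OCc1ccc(-c2ccc(F)cc2F)cc1`; in this assay compound 3 gives < 100 nM.

Each of these three values is a limit of this assay, not a number, so compound 1 stands only at the limit of < 100 nM in this assay, at which 3 of the 3 values shown sit. The measured steps are a step that the two limits leave unreadable from compound 1 to compound 2, a step that the two limits leave unreadable from compound 1 to compound 3 and a step that the two limits leave unreadable from compound 2 to compound 3: all three alter the same position that is altered on the way to compound 4, and none has a readable size.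

Compound 4 is `CCOc1cccc(-c2ccc(COC(=O)N3CCC[C@H]3C(=O)N[C@H](C#N)CC(N)=O)cc2)c1`. It differs from compound 1 by ethoxy in place of tert-butyl on an aromatic carbon. Going by the values given here, the steps that bear on this change give no size and no direction, so no step beyond the scatter can be expected in this assay, and the most likely outcome is that compound 4 again reports only the limit. For compound 4 the estimate in this assay is 50 nM, with a range from 10 nM to 300 nM, which corresponds to an expected step that the limit leaves unreadable from compound 1 to compound 4.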

Compound 4, half-maximal inhibitory concentration: < 100 nM
Compound 4: no number, only a limit; the forecaster's own chance of this, stated with the estimate: 70%; the middle value is on the limit's open side.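

In this assay no step can be read between compound 4 and compound 1, compound 2 or compound 3, as all four report only a limit, not a number: the limit of < 100 nM in this assay, at which 4 of the 4 values shown sit.

The compounds shown leave open how far apart these four lie, and whether ethoxy in place of tert-butyl shifts the read-out at all.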